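The compounds below may be only part of what the source reports. "The series", "measured", "known", "first", "only" and "open" are said of these compounds alone.

Three measured compounds span a narrow band in a functional assay on PC-3 cells (Homo sapiens) for cytotoxicity; a higher number here means a weaker inhibitor, a lower number a stronger inhibitor. Compound 1 `C=C1C[C@@H](OC(C)=O)[C@@H](C(C)C)[C@@H]2[C@@H](C(C)=O)[C@@H](OC(=O)/C(C)=C\C)C[C@@H]12` gives 78700 nM; compound 2 `C/C=C(/C)C(=O)O[C@H]1C[C@@H](O)C2=CC(=O)C(C(C)(C)OO)=C[C@]2(C)[C@H]1C` gives 16500 nM; compound 3 `C/C=C(/C)C(=O)O[C@H]1C[C@@H](O)C2=CC(=O)C(=C(C)C)C[C@]2(C)[C@H]1C` gives 33200 nM. Compound 3 thus holds the second-highest of the three numbers: its value and that of compound 2 sit within the scatter of each other, while compound 1 returns a higher number than compound 3 by a margin beyond the scatter.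

Compound 4 `C/C=C(/C)C(=O)O[C@H]1C[C@@H](OC(=O)/C(C)=C/C)C2=CC(=O)C(=C(C)C)C[C@]2(C)[C@H]1C` differs from compound 3 in one place: (1-methylprop-1-en-1-yl)carbonyl in place of hydrogen on an oxygen on a saturated carbon. Within the data shown here, no measured pair shows this change, so the expected step is set at none beyond the scatter, a 1.2-fold higher number from compound 3 to compound 4 (0.08 log units; within the scatter), leaning slightly toward a higher number. Compound 4 is accordingly estimated at 40000 nM in this assay, within 12000 nM to 130000 nM.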

Compound 4, half-maximal inhibitory concentration: 10700 nM
Compound 4: the middle estimate sits 3.7-fold (0.57 log units) above what was measured; the whole stated range lies above it.
By their numbers in this assay, from the lowest: compounds 4, 2 and 3 (each within the scatter of the next, the first and the last beyond it); then compound 1.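

In this assay, among these compounds, replacing hydroxy with ((1-methylprop-1-en-1-yl)carbonyl)oxy gives a 3.1-fold lower number from compound 3 to compound 4 (0.49 log units; beyond the scatter), the only step read at this position. A free hydroxy on this saturated carbon is therefore not needed for this read-out in this pair, and the added group goes with a lower number rather than a higher one. Nothing at hand bears on why the number moves. Going by these compounds, whether the lower number is specific to this group or follows from any acyl group on that oxygen stays open. A benzoyl or an aminoacetyl group at the same place would separate these two readings.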